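A few compounds are considered here, and "the series" means these few. Any claim that something is new, unique, unknown or untested is made for them only; others in the source may bear on it.

Compound 1 `COc1ccnc(C[S+]([O-])c2nc3cc(OCC(F)(F)F)ccc3[nH]2)c1C`: 0.15 h
Compound 2 `COc1ccnc(C[S+]([O-])c2nc3cc(OC(F)(F)C(F)F)ccc3[nH]2)c1OC`: 3.6 h
Compound 3 `COc1cnc(C[S+]([O-])c2nc3cc(OC(F)(F)C(F)F)ccc3[nH]2)c(C)c1OC`: 6.8 h

In an ADME assay, at pH 5 (a higher number here means that the compound lasts longer, a lower number that the compound disappears faster), compound 3 gives 6.8 h and compound 2 gives 3.6 h, two values within the scatter of each other. Both lie well above compound 1 at 0.15 h, and the gap from compound 3 to compound 1 is clearly beyond the scatter.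

Compound 4 `COc1ccnc(C[S+]([O-])c2nc3cc(OC(F)(F)C(F)F)ccc3[nH]2)c1C` follows from compound 3 with hydrogen in place of methoxy on an aromatic carbon. Among the compounds with values here, no measured pair isolates this change, so the expectation rests on neighbouring compounds. Compound 4 shares the substitution of that ring with compound 1 (0.15 h), while the rest of its structure matches compound 3 (6.8 h). A value between these two is therefore expected. The expected step in this assay is a fall beyond the scatter (a 5.7-fold lower number from compound 3 to compound 4 (0.75 log units; beyond the scatter)). Compound 4 is estimated to give 1.2 h (expected range 0.4 h to 3.5 h).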

Compound 4, half-life: 0.3 h
The estimate for compound 4 lay 4.0-fold (0.60 log units) above the measured number, outside the stated range (below it).
By their numbers in this assay, from the lowest: compounds 1 and 4 (each within the scatter of the next); then compounds 2 and 3 (each within the scatter of the next).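

In this assay, hydrogen in place of methoxy on an aromatic carbon gives a 23-fold lower number from compound 3 to compound 4 (1.36 log units; beyond the scatter) and so counts as a large step, which shows that the half-life depends strongly on this methoxy group, ortho to a methoxy group and two atoms from the ring nitrogen. Methyl in place of methoxy on an aromatic carbon also gives a large fall, a 12-fold lower number from compound 2 to compound 4 (1.08 log units; beyond the scatter) in this case, so a second methoxy swap on that ring matters as well. By contrast, 1,1,2,2-tetrafluoroethyl in place of 2,2,2-trifluoroethyl gives a 2.0-fold higher number from compound 1 to compound 4 (0.30 log units; within the scatter) and stays within the scatter, so the chain on the oxygen does not account for the wide gap among the earlier compounds.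

As far as these compounds go, whether an ethoxy group or a chlorine atom at this place would keep the longer half-life remains open. The data shown offer no evidence on why these swaps have such different effects.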